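Methoxy in Place of Chloro: an Expected Cytotoxicity Value

The source may report more compounds than this note shows. Statements on the series, on what has been measured and on what is new or still open speak of the compounds shown alone.

Compound 1, `O=C1CSC(c2ccc(Cl)cc2)N1CCN1CCCCC1`, gives 11% in an ADME assay on Vero cells (Chlorocebus sabaeus) for cytotoxicity, read by neutral red uptake, tested at 3150 ug/mL; on this read-out higher numbers stand for a weaker effect at the one concentration tested and lower numbers for a stronger effect.
Compound 2, `O=C1CSC(c2ccccc2Cl)N1CCN1CCCCC1`, gives 22% in this assay.
Compound 3, `O=C1CSC(c2c(Cl)cccc2Cl)N1CCN1CCCCC1`, gives 7% in this assay.

Among these three numbers compound 1 stands second highest. Its nearest neighbour is compound 3, whose number is lower by an amount within the scatter, so the two cannot be told apart. Its furthest is compound 2, reached by the step of a number 11 percentage points higher from compound 1 to compound 2 (beyond the scatter), which moves the chloro to another aromatic carbon. The other step, a number 15 percentage points lower from compound 2 to compound 3 (beyond the scatter), adds a second chloro. Both steps are modest.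

Compound 4, `COc1ccc(C2SCC(=O)N2CCN2CCCCC2)cc1`, differs from compound 1 in one place: methoxy in place of chloro on an aromatic carbon. Among the compounds with values here, neither measured step exchanges chloro for methoxy, so neither bears on this change directly; they show only that changes to the chloro pattern move this assay by modest amounts. An account resting on these steps expects a step of similar size at most, with no clear direction. Compound 4 is therefore estimated at 14%, between 3% and 32%, which is an expected step of a number 3 percentage points higher from compound 1 to compound 4 (within the scatter).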

Compound 4, a percentage reported as activity, at one concentration (the size of the read-out at that concentration, not a potency): 11%
Beside the measured number, compound 4's estimate is 3 percentage points above it; low and high end bracket the measured number.
By their numbers in this assay, from the lowest: compounds 3, 1 and 4 (each within the scatter of the next); then compound 2.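

In this assay, methoxy in place of chloro on an aromatic carbon para to a large group gives no change at the digits printed from compound 1 to compound 4 (within the scatter) and is the first change shown that replaces the chloro rather than moving it or adding a second one. At this position, then, the read-out does not separate chloro from methoxy, even though methoxy brings one more heavy atom and a hydrogen-bond acceptor that chloro lacks. Nothing available explains why the two groups read alike.

The compounds shown leave open whether an amine, a carboxylic acid or a longer chain such as butoxy in this place would also leave the number unmoved. They also leave open whether methoxy would follow chloro in changing the number when placed as the chloro is in compound 2.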